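A few compounds are considered here, and "the series" means these few. Any claim that something is new, unique, unknown or untested is made for them only; others in the source may bear on it.

Measured so far:
compound 1, `C[C@@H](O[C@H]1CN2C(=O)C=C(c3ccc(C#N)cc3)CC2[C@@H]1c1ccc(F)cc1)c1cc(C(F)(F)F)cc(C(F)(F)F)c1` — 53 nM
compound 2, `C[C@@H](O[C@H]1CN2C(=O)C=C(c3cc[n+]([O-])cc3)CC2[C@@H]1c1ccc(F)cc1)c1cc(C(F)(F)F)cc(C(F)(F)F)c1` — 2.1 nM

In an assay on CHO cells for displacement of a labelled ligand from Substance-P receptor (Homo sapiens), in the presence of a further agent that is not named here (on this read-out lower numbers stand for stronger inhibition and higher numbers for weaker inhibition), compound 1 gives 53 nM and compound 2 gives 2.1 nM. Compound 2 holds the lower of the two numbers, the step of a 25-fold lower number from compound 1 to compound 2 (1.40 log units; beyond the scatter) being large and well beyond the scatter. The next compound, compound 3, `C[C@@H](O[C@H]1CN2C(=O)C=C(c3cc[nH]c(=O)c3)CC2[C@@H]1c1ccc(F)cc1)c1cc(C(F)(F)F)cc(C(F)(F)F)c1`, differs from compound 2 by a group of 7 heavy atoms (5 carbon, 1 nitrogen, 1 oxygen; one six-membered aromatic ring with 1 hetero atom) in place of a group of 7 heavy atoms (5 carbon, 1 nitrogen, 1 oxygen; one six-membered aromatic ring with 1 hetero atom), on a double-bonded ring carbon; the two contain the same atoms joined differently. Within the data shown here, only one measured step touches this position, and it was large, so a change here can move the number substantially; no measured pair shows this exact exchange, however, so the direction rests on the fact that compound 2 already holds the lowest number. The step of a 3.8-fold higher number from compound 2 to compound 3 (0.58 log units; beyond the scatter) is the expected outcome. Compound 3 is estimated at 8 nM, with a range from 2 nM to 40 nM.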

Compound 3, half-maximal inhibitory concentration: 3.9 nM
For compound 3 the middle estimate is 2.1-fold (0.31 log units) above the measured one, and the stated range covers the measured number.
By their numbers in this assay, from the lowest: compounds 2 and 3 (each within the scatter of the next); then compound 1.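

In this assay joining the same atoms differently on the double-bonded ring carbon, which gives the ring a hydrogen-bond donor, leaves a 1.9-fold higher number from compound 2 to compound 3 (0.27 log units; within the scatter) and so separates the two rings by no more than repeat measurements would. The large gain over the nitrile-bearing carbon ring of compound 1 therefore appears with a second six-membered aromatic ring with one hetero atom, as a 14-fold lower number from compound 1 to compound 3 (1.13 log units; beyond the scatter) shows. Nothing available here accounts for these numbers.

The compounds shown leave open whether the oxygen on these rings is needed, which a plain pyridine ring or an aminopyridine at this carbon would address. They also leave open whether a ring nitrogen is needed at all, which a carbon-only ring bearing a carboxylic acid would test.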